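Indole change on compound 2

The source may hold more compounds than are shown below. What is called first, only, known or untested is meant among the compounds shown, and "the series" means these compounds.

Measured in a functional assay on HCT-116 cells (Homo sapiens) for antiproliferative activity, read by MTT assay, with a stated time of 48 h (on this read-out higher numbers stand for weaker inhibition and lower numbers for stronger inhibition), so far:
compound 1 `COc1ccc(/C=C/C=C\c2cc(OC)c(OC)c(OC)c2)cc1O` gives 42.3 nM
compound 2 `CCOc1cc(-c2ccc3cc[nH]c3c2)cn2c(-c3cc(OC)c(OC)c(OC)c3)nnc12` gives 1340 nM
compound 3 `COc1cc(-c2nnc3c(OC)cc(-c4ccc5[nH]ccc5c4)cn23)cc(OC)c1OC` gives 108 nM

Compound 2 stands highest of the three numbers, and compound 3 and compound 1 both lie lower by more than the scatter. This makes compound 2 the weakest inhibitor so far in this assay and leaves clear room for improvement.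

Next in the series is compound 4 `CCOc1cc(-c2ccc3c(ccn3C)c2)cn2c(-c3cc(OC)c(OC)c(OC)c3)nnc12` which is still unmeasured. The change from compound 2 to compound 4 is 1-methyl-1H-indol-5-yl in place of 1H-indol-6-yl on an aromatic carbon and it sits meta to an ethoxy group.

Among the compounds with values here, no measured pair isolates this change, so the expectation rests on thin ground. The nearest guide is compound 3 at 108 nM which points toward a lower number than compound 2 shows. The expected change is a 4.5-fold lower number from compound 2 to compound 4 (0.65 log units; beyond the scatter) as a moderate gain beyond the scatter, though no change at all cannot be excluded. Compound 4 is estimated at 300 nM with an expected range from 70 nM to 1500 nM in this assay.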

Compound 4, half-maximal inhibitory concentration: 228 nM
Beside the measured number, compound 4's estimate is 1.3-fold (0.12 log units) above it, and the stated range covers the measured number.
By their numbers in this assay, from the lowest: compound 1; then compound 3; then compound 4; then compound 2.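

Within the data shown here, replacing 1H-indol-6-yl with 1-methyl-1H-indol-5-yl gives a 5.9-fold lower number from compound 2 to compound 4 (0.77 log units; beyond the scatter) in this assay and is the first step to isolate a change on this aromatic carbon, with the ethoxy group held in place. Compound 4 reaches 228 nM without a hydrogen-bond donor on this group, so that donor is not required for activity at this level. The swap moves the attachment point and adds the methyl on the indole nitrogen together, and no information is available on why the number falls.

This single step does not divide the gain between the attachment point and the methyl. Going by these compounds, how this position responds to a longer chain on the indole nitrogen, such as ethyl, or to an amine on the indole also remains open.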